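A few compounds are considered here, and "the series" means these few. Any claim that something is new, unique, unknown or untested is made for them only; others in the source may bear on it.

Measured so far:
- compound 1 `CC(C)=CCc1cc(C(=O)Nc2cc3ccc(OCC4CCCN(C)C4)c(C)c3oc2=O)ccc1O` — 1300 nM
- compound 2 `CC(C)=CCc1cc(C(=O)Nc2cc3ccc(OCC4CCN(C)C4)c(C)c3oc2=O)ccc1O` — 920 nM
- compound 3 `CCCNCCCOc1ccc2cc(NC(=O)c3ccc(O)c(CC=C(C)C)c3)c(=O)oc2c1C` — 990 nM

In a functional assay on SK-BR-3 cells (Homo sapiens) for antiproliferative activity (a higher number here means a weaker inhibitor, a lower number a stronger inhibitor), compound 2 gives 920 nM. This is the lowest of the three numbers, but its separation from the other two is small: a 1.4-fold lower number from compound 1 to compound 2 (0.15 log units; within the scatter) and a 1.1-fold higher number from compound 2 to compound 3 (0.03 log units; within the scatter) both sit within the scatter, so the three compounds are indistinguishable on these numbers. Across the set, the only part that varies is the group on the saturated chain carbon bound to the oxygen on the aromatic ring; every variation so far, including a 1.3-fold lower number from compound 1 to compound 3 (0.12 log units; within the scatter), has left the read-out essentially unchanged.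

Compound 4 `CC(C)=CCc1cc(C(=O)Nc2cc3ccc(OCCCNCc4ccccc4)c(C)c3oc2=O)ccc1O` has not yet been measured. Relative to compound 2 the change is 2-(benzylamino)ethyl in place of 1-methylpyrrolidin-3-yl on a saturated chain carbon bound to an oxygen on an aromatic ring. Going by the values given here, the closest precedent is the step to compound 3, in which the same 1-methylpyrrolidin-3-yl was exchanged for an open-chain amine-bearing group, and that step stayed within the scatter. On that basis a step of a 1.0-fold lower number from compound 2 to compound 4 (0.01 log units; within the scatter) is expected, i.e. nothing beyond the scatter in either direction. Compound 4 is therefore estimated at 900 nM, with a range of 400 nM to 2000 nM.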

Compound 4, half-maximal inhibitory concentration: 470 nM
Compound 4: the middle estimate sits 1.9-fold (0.28 log units) above what was measured, and the stated range covers the measured number.
By their numbers in this assay, from the lowest: compounds 4, 2, 3 and 1 (each within the scatter of the next, the first and the last beyond it).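

In this assay, going by these compounds alone, compound 4 is the only compound with steps beyond the scatter: a 2.1-fold lower number from compound 3 to compound 4 (0.32 log units; beyond the scatter) and a 2.8-fold lower number from compound 1 to compound 4 (0.44 log units; beyond the scatter) are both modest, whereas a 2.0-fold lower number from compound 2 to compound 4 (0.29 log units; within the scatter) stays within it, so the change at this position separates compound 4 from two of its neighbours but not from compound 2. The step from compound 3 is the narrowest comparison, with phenyl in place of ethyl on a saturated chain carbon bound to an amine nitrogen, and it shows that the group carried on the amine of the open chain can shift the read-out, not only the exchange of one amine-bearing group for another. No available data explain this shift.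

On these data alone, it remains open whether the aromatic ring itself matters, which a cyclohexylmethyl group on the same amine would test, and whether a phenethyl group or a fluorine or methoxy substituent on the benzyl ring would carry the trend further. The role of the amine nitrogen is also unresolved, and an amide or an ether linkage in its place would address it.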